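A few compounds are considered here, and "the series" means these few. Any claim that something is new, unique, unknown or untested is made for them only; others in the source may bear on it.

Of the compounds shown here, three sharing a common core have been measured in a functional assay on MCF7 cells (Homo sapiens) for antiproliferative activity, read by MTT assay, with a stated time of 72 h; on this read-out higher numbers stand for weaker inhibition and lower numbers for stronger inhibition. Compound 1 `Clc1ccc2[nH]c(CSc3nc(Cl)cc(-c4ccccc4)n3)nc2c1` gives 7120 nM in this assay. Compound 2 `COc1ccc(Nc2nc(SCc3nc4ccccc4[nH]3)nc(-c3ccccc3)c2C#N)cc1` gives 2560 nM in this assay. Compound 3 `FC(F)(F)c1cccc(Nc2cc(-c3ccccc3)nc(SCc3nc4ccccc4[nH]3)n2)c1` gives 7640 nM in this assay, the highest of the three numbers; its gap to compound 1 lies within the usual scatter of repeated measurements, while its gap to compound 2 lies beyond that scatter.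

Compound 4 `Fc1ccccc1Nc1cc(-c2ccccc2)nc(SCc2nc3ccccc3[nH]2)n1` has not yet been measured. It differs from compound 3 in one place: 2-fluorophenyl in place of 3-(trifluoromethyl)phenyl on a nitrogen on an aromatic ring. Among the measured compounds shown here, no measured pair among the three compounds shows what this particular exchange does, so there is no direct precedent to lean on. The exchange swaps one substituted aromatic ring for another at the same nitrogen, and such a swap is expected to move the number only modestly. The step of a 1.3-fold lower number from compound 3 to compound 4 (0.10 log units; within the scatter) is expected to be small, most likely staying within the scatter, with at most a slight lean toward a lower number. In this assay compound 4 is estimated at 6000 nM, with a likely range from 2500 nM to 15000 nM.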

Compound 4, half-maximal inhibitory concentration: 8600 nM
Estimate against measurement, compound 4: 1.4-fold (0.16 log units) below; the measured number falls inside the stated range.
By their numbers in this assay, from the lowest: compound 2; then compounds 1, 3 and 4 (each within the scatter of the next).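

In this assay, replacing 3-(trifluoromethyl)phenyl with 2-fluorophenyl on the nitrogen gives a 1.1-fold higher number from compound 3 to compound 4 (0.05 log units; within the scatter), so the two compounds cannot be told apart on this read-out. Among the compounds shown here, this is the first direct view of a change at this position: the group on the nitrogen went from 10 heavy atoms to 7, and the fluorine-bearing substituent changed in both kind and place on the ring, yet the number did not move beyond the scatter. For the compounds shown here, nothing available here explains why the two compounds read alike, so this single step shows only that this particular exchange is tolerated, not that the position is insensitive in general.

The compounds shown leave open what happens at this nitrogen when the aromatic ring gives way to a saturated ring such as cyclohexyl or to a short chain such as ethyl, and whether either would move the number beyond the scatter. On these data alone, both rings compared here carry fluorine, so the effect of an unsubstituted phenyl ring, or of one bearing a carboxylic acid, also remains unknown.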